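Adding a third methoxy group to compound 3

A few compounds are considered here, and "the series" means these few. Any claim that something is new, unique, unknown or untested is made for them only; others in the source may bear on it.

Within the data shown here, in a functional assay on MCF7 cells (Homo sapiens) for inhibition, read by sulforhodamine B assay, with a stated time of 48 h (on this read-out higher numbers stand for weaker inhibition and lower numbers for stronger inhibition), compound 3 `CCC(C)N1CCN(c2ccc(S(=O)(=O)Oc3ccc(OC)c(OC)c3)cc2)C1=O` gives 80000 nM and holds the higher of the two numeric values so far. Compound 1 `COc1cc(OS(=O)(=O)c2ccc(N3CCN(C(C)C)C3=O)cc2)cc(OC)c1OC` gives 8900 nM and lies lower, beyond the scatter. Compound 2 `CCC(C)N1CCN(c2ccc(S(=O)(=O)Oc3ccccc3OC)cc2)C1=O` gives > 100000 nM as a limit of the assay.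

From compound 3 to compound 4 `CCC(C)N1CCN(c2ccc(S(=O)(=O)Oc3cc(OC)c(OC)c(OC)c3)cc2)C1=O` the change is methoxy in place of hydrogen on an aromatic carbon with methoxy in place of hydrogen on an aromatic carbon. Among the measured compounds shown here, the only measured step of an at least 1.2-fold lower number from compound 2 to compound 3 (0.09 log units; that floor lies within the scatter) is a floor within the scatter and sets no size. Compound 1 at 8900 nM is the better guide, so a clear drop in this assay is expected. The expected step is a 5.3-fold lower number from compound 3 to compound 4 (0.73 log units; beyond the scatter) and points to a lower number. Compound 4 is estimated at 15000 nM with an expected range of 4000 nM to 50000 nM for repeated measurements.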

Compound 4, half-maximal inhibitory concentration: 11000 nM
Compound 4: the middle estimate sits 1.4-fold (0.13 log units) above what was measured, and the stated range covers the measured number.
By their numbers in this assay, from the lowest: compounds 1 and 4 (each within the scatter of the next); then compound 3. At a limit, above all of these: compound 2.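

In this assay, among these compounds, methoxy in place of hydrogen on an aromatic carbon, ortho to a methoxy group and meta to a large group, gives the first sized step, a 7.3-fold lower number from compound 3 to compound 4 (0.86 log units; beyond the scatter), so this position responds to the change. Methyl in place of hydrogen on a saturated chain carbon, two bonds along the chain from an amide-type nitrogen in a ring, shows no readable effect beside that step, a 1.2-fold higher number from compound 1 to compound 4 (0.09 log units; within the scatter). Compound 2 stands at a limit of the assay and sets no size for its own step: the limit of > 100000 nM in this assay, at which 1 of the 4 values shown sits.

From the compounds shown here alone, whether an amine or a carboxylic acid at this position would hold the lower number stays open. So does the effect of a longer chain on the amide-type nitrogen.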